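A Methoxy Group Tested Against Leukemia Cells

The compounds below may be only part of what the source reports. "The series", "measured", "known", "first", "only" and "open" are said of these compounds alone.

Of the compounds shown here, three have so far been measured in a functional assay on K562 cells (Homo sapiens) for cytotoxicity, read by MTT assay, with a stated time of 72 h; on this read-out higher numbers stand for weaker inhibition and lower numbers for stronger inhibition. Compound 1 `COc1ccc2c(c1)[n+]([O-])nc(NCOC(C)c1ccccc1)[n+]2[O-]` gives 250 nM. Compound 2 `CC(OCNc1n[n+]([O-])c2ccccc2[n+]1[O-])c1ccccc1` gives 2240 nM in this assay, and compound 3 `CCCCCOCNc1n[n+]([O-])c2ccccc2[n+]1[O-]` gives 3300 nM. Compound 1 and compound 2 share a core and differ in one place, (methoxy in place of hydrogen on an aromatic carbon), a change that produced a 9.0-fold lower number from compound 2 to compound 1 (0.95 log units; beyond the scatter). Compound 3 carries a different side chain on the same kind of core; how compound 3 differs from compound 2 is not broken down here, and the two values of compound 2 and compound 3 lie within the usual scatter of each other.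

Compound 4 `CCCCCOCNc1n[n+]([O-])c2cc(OC)ccc2[n+]1[O-]` has not yet been measured. It differs from compound 3 by methoxy in place of hydrogen on an aromatic carbon, the same change as from compound 2 to compound 1, made at the same place. In this assay compound 4 is expected to come out near 400 nM, roughly between 150 nM and 1100 nM. This expectation rests on compound 3 at 3300 nM and on the earlier step of a 9.0-fold lower number from compound 2 to compound 1 (0.95 log units; beyond the scatter), so the step expected for compound 4 is an 8.3-fold lower number from compound 3 to compound 4 (0.92 log units; beyond the scatter), of about the same size. Going by the values given here, with only one prior example of the change, the actual outcome may well fall short of or exceed that.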

Compound 4, half-maximal inhibitory concentration: 450 nM
For compound 4 the middle estimate is 1.1-fold (0.05 log units) below the measured one, within the range that was stated.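

In this assay, methoxy in place of hydrogen on an aromatic carbon again gave a clear change, a 7.3-fold lower number from compound 3 to compound 4 (0.87 log units; beyond the scatter), and it closely matches the earlier step: the same change on two cores in this assay, a 9.0-fold lower number (0.95 log units; beyond the scatter) from compound 2 to compound 1 and a 7.3-fold lower number (0.87 log units; beyond the scatter) from compound 3 to compound 4, 1.2-fold (0.09 log units) apart, within the scatter of two such steps. Once methoxy is present, pentyl in place of 1-phenylethyl makes no clear difference, a 1.8-fold higher number from compound 1 to compound 4 (0.26 log units; within the scatter). Going by these compounds alone, this shows that the change carried over between these two side chains, but with only two examples on closely related compounds, it does not show that the same step would appear on a different core, nor does it explain why the number falls.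

The compounds shown leave open whether another group at the same place, such as an amine or a carboxylic acid, would give a step of similar size, and whether methoxy would do so elsewhere on that ring. They also leave open whether a longer chain in place of pentyl would change the value of a methoxy compound.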